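Swapping Methyl for Methoxy on the Aromatic Ring

This account rests on a few compounds, and the source may have more. Where it says the series, first, only, none or still open, it means among the compounds named here.

Of the compounds shown here, two have been tested in a functional assay on SW1573 cells (Homo sapiens) for inhibition, read by sulforhodamine B assay, with a stated time of 48 h; on this read-out lower numbers stand for stronger inhibition of growth and higher numbers for weaker inhibition of growth. Compound 1 `COC(=O)[C@@]1(C)CCC=C2[C@@H]1CC[C@@H](C)[C@]2(C)Cc1c(C)[nH]c2c(Br)cccc12` gives 25000 nM, and compound 2 `COC(=O)[C@@]1(C)CC[C@@H]2C3=C1CC[C@@H](C)[C@]3(C)Cc1c2[nH]c2ccc(C)cc12` gives 15000 nM. Compound 2 stands at the lowest of the two numbers shown, with compound 1 inside the usual scatter of it. Compound 3 `COC(=O)[C@@]1(C)CC[C@@H]2C3=C1CC[C@@H](C)[C@]3(C)Cc1c2[nH]c2ccc(OC)cc12` differs from compound 2 by a single change: methoxy in place of methyl on an aromatic carbon. Among the measured compounds shown here, no measured pair of this kind exists, so no step beyond the scatter is expected in this assay, in either direction. Compound 3 is therefore expected to give 15000 nM, within a range from 5000 nM to 45000 nM. This corresponds to an expected step of no change at the digits printed from compound 2 to compound 3 (within the scatter).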

Compound 3, concentration for 50% growth inhibition: 5900 nM
Compound 3: the middle estimate sits 2.5-fold (0.41 log units) above what was measured, within the range that was stated.
By their numbers in this assay, from the lowest: compound 3; then compounds 2 and 1 (each within the scatter of the next).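

In this assay, this aromatic carbon, para to a fused ring, is sensitive to the group it carries: methoxy in place of methyl gives a 2.5-fold lower number from compound 2 to compound 3 (0.41 log units; beyond the scatter) in a modest step beyond the scatter. Among the compounds shown here, this is the first pair to show that this swap, which brings in one oxygen and one hydrogen-bond acceptor, can lower the number. No available evidence explains the step.

Open, from the compounds shown here alone, is how a hydroxyl, an ethoxy chain or an amine on this same carbon would compare. That comparison would help show whether the oxygen itself or simply the longer group goes with the lower number.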